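A few compounds are considered here, and "the series" means these few. Any claim that something is new, unique, unknown or untested is made for them only; others in the source may bear on it.

Working notes on the series in a physicochemical assay for solubility, read by HPLC, using the shake flask method, measured as kinetic solubility, with a stated time of 2 h, at pH 7.4; a higher number here means a more soluble compound, a lower number a less soluble compound. Compound 1 `Cc1cc(NCc2nccn2C)n2nc(C)c(-c3ccccc3)c2n1` gives 26900 nM in this assay. Compound 2 `Cc1cc(NCc2ccccn2)n2ncc(-c3ccccc3F)c2n1` gives 5000 nM, the lowest of the two numbers shown; compound 1 is its nearest neighbour, with a higher number beyond the scatter. Compound 3 `Cc1cc(NCc2ccccn2)n2nc(C)cc2n1` returns > 200000 nM, which is a limit of the assay and not a number. Of the values shown, (the limit of > 200000 nM in this assay, at which 1 of the 3 values shown sits). Within the data shown here, no two measured compounds differ in one place, so no measured step is available. Compound 4 `Cc1cc(NCc2ccccn2)n2ncc(-c3cccc(N(C)C)c3)c2n1` differs from compound 2 by 3-(dimethylamino)phenyl in place of 2-fluorophenyl on an aromatic carbon. This change is expected to give no step beyond the scatter, estimated as a 1.6-fold higher number from compound 2 to compound 4 (0.20 log units; within the scatter). For compound 4 the expected value in this assay is 8000 nM, with a range from 2000 nM to 30000 nM.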

Compound 4, solubility: 94600 nM
Compound 4: middle estimate off by 12-fold (1.07 log units), on the low side, and the stated range ends below it.
By their numbers in this assay, from the lowest: compound 2; then compound 1; then compound 4. At a limit, above all of these: compound 3.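

In this assay, this aromatic carbon of the five-membered ring proves sensitive to the aryl group it carries, with 3-(dimethylamino)phenyl in place of 2-fluorophenyl giving a 19-fold higher number from compound 2 to compound 4 (1.28 log units; beyond the scatter). The step reads in full, since neither of its compounds sits at the limit of the assay, which belongs to compound 3 alone: the limit of > 200000 nM in this assay, at which 1 of the 4 values shown sits.

From the compounds shown here alone, whether the step follows the entering dimethylamino group or the departing fluorine stays open, as this single pair changes both together. Going by these compounds, how a primary amine or a methoxy group on that phenyl ring would read is also open.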